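This account rests on a few compounds, and the source may have more. Where it says the series, first, only, none or still open, it means among the compounds named here.

In a toxicity assay on HaCaT cells (Homo sapiens) for cytotoxicity, read by CCK-8 assay, with a stated time of 24 h (on this read-out lower numbers stand for higher toxicity in this test and higher numbers for lower toxicity in this test), compound 1 `COc1ccccc1Oc1c(N)nc(-c2ccccc2)nc1Cl` gives "not active" (no number reported) and no number. Compound 2 `COc1ccccc1Oc1c(N)nc(-c2ccc(C)cc2)nc1Cl` gives 6300 nM. Among the compounds with values here, compound 3 `COc1ccc(-c2nc(N)c(Oc3ccccc3OC)c(Cl)n2)cc1` gives 8200 nM, level with compound 2 as one of only two numbers. Compound 4 `COc1ccccc1Oc1c(N)nc(-c2cccc(Br)c2)nc1Cl` carries 3-bromophenyl in place of 4-methoxyphenyl on an aromatic carbon. Within the data shown here, the only measured step, a 1.3-fold higher number from compound 2 to compound 3 (0.11 log units; within the scatter), is small and within the scatter, but it concerns methoxy in place of methyl and does not test a 3-bromophenyl group. Compound 1 adds no number, so the data give no firm direction. Expected is a 1.4-fold lower number from compound 3 to compound 4 (0.14 log units; within the scatter), which means no step beyond the scatter. The estimated value for compound 4 is 6000 nM, with an expected range of 2000 nM to 16000 nM.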

Compound 4, half-maximal cytotoxic concentration: 16100 nM
The estimate for compound 4 lay 2.7-fold (0.43 log units) below the measured number, and the stated range ends below it.
By their numbers in this assay, from the lowest: compounds 2, 3 and 4 (each within the scatter of the next, the first and the last beyond it).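

In this assay, within the data shown here, replacing the aryl group on the carbon between the two ring nitrogen atoms gives the first step beyond the scatter, though a modest one: a 2.6-fold higher number from compound 2 to compound 4 (0.41 log units; beyond the scatter). The other step, a 2.0-fold higher number from compound 3 to compound 4 (0.29 log units; within the scatter), stays within the scatter, so 3-bromophenyl separates only from 4-methylphenyl and not from 4-methoxyphenyl. No measured evidence accounts for this difference.

Both steps change the substituent and its ring location together, so the contribution of each remains unresolved. From the compounds shown here alone, how a phenyl group carrying an amine or a carboxylic acid would read at this position also remains open.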